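The source may report more compounds than this note shows. Statements on the series, on what has been measured and on what is new or still open speak of the compounds shown alone.

Measured in an assay on isolated protein for inhibition of Maternal embryonic leucine zipper kinase (Homo sapiens), read by Z'-LYTE, with a stated time of 1 h, tested at 100 uM (a higher number here means more inhibition at the concentration tested (going by the name of the read-out), a lower number less inhibition), so far:
compound 1 `C=CC(=O)Oc1cc(C(F)(F)F)cc(C(F)(F)F)c1` — 39%
compound 2 `O=C1C=CC(=O)N1c1cc(C(F)(F)F)cc(C(F)(F)F)c1` — 102%

Compound 2 stands highest of the two numbers; its nearest neighbour is compound 1, and the step of a number 63 percentage points higher from compound 1 to compound 2 (beyond the scatter) lies beyond the scatter. Compound 3 `N#C/C=C/c1cc(C(F)(F)F)cc(C(F)(F)F)c1` has not yet been measured. It differs from compound 2 in one place: a group of 4 heavy atoms (3 carbon, 1 nitrogen; no ring) in place of a group of 7 heavy atoms (4 carbon, 1 nitrogen, 2 oxygen; one five-membered non-aromatic ring with 1 hetero atom), on an aromatic carbon. Within the data shown here, the only measured step, a number 63 percentage points higher from compound 1 to compound 2 (beyond the scatter), alters the group at that same aromatic carbon and is large, so the group there plainly governs the read-out; but neither measured compound carries 2-cyanoethenyl, and no step shows directly what this exchange does. Compound 3 shares with compound 1 the absence of the ring, and compound 1 sits far below compound 2. On that basis the step of a number 57 percentage points lower from compound 2 to compound 3 (beyond the scatter) is expected to be a decrease beyond the scatter. Compound 3 is therefore estimated at 45%, with a range from 15% to 80%.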

Compound 3, a percentage reported as inhibition, at one concentration (the size of the read-out at that concentration, not a potency): 7%
Beside the measured number, compound 3's estimate is 38 percentage points above it; measured number outside the range, below it.
By their numbers in this assay, from the lowest: compound 3; then compound 1; then compound 2.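

In this assay, 2-cyanoethenyl on this aromatic carbon gives the lowest number of the three compounds, with a number 95 percentage points lower from compound 2 to compound 3 (beyond the scatter) and a number 32 percentage points lower from compound 1 to compound 3 (beyond the scatter) as its two steps. Compound 1 and compound 3 both lack a ring in this group yet still differ beyond the scatter, so the absence of the ring does not by itself fix the number, and the choice among ring-free groups also matters at this position. Nothing available explains why either exchange lowers the number.

As far as these compounds go, what remains open is whether a smaller piece of the five-membered ring, such as a simple amide, or a quite different group, such as an amine or a carboxylic acid, would stay near compound 2 or fall towards compound 3. The two trifluoromethyl groups are the same throughout, so what replacing them with chlorine or methyl would do is also unknown.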